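This account rests on a few compounds, and the source may have more. Where it says the series, first, only, none or still open, it means among the compounds named here.

Measured in a functional assay (muscle tissue) with Cavia porcellus as the target; a lower number here means that less compound is needed, a higher number that more compound is needed for the effect:

- Compound 1 `COC(=O)C1=C(C)N=C(C)/C(=C(\O)OC)C1c1c(F)c(F)c(F)c(F)c1F`: 4.37 nM
- Compound 2 `COC(=O)C1=C(C)N=C(C)/C(=C(\O)OC)C1c1cc(OC)c(OC)cc1OC`: 1000000 nM
- Compound 3 `COC(=O)C1=C(C)N=C(C)/C(=C(\O)OC)C1c1ccccc1C(F)(F)F`: 1.51 nM

Of these three, compound 3 has the lowest number at 1.51 nM. Its nearest neighbour is compound 1 at 4.37 nM, a gap beyond the usual scatter, and furthest away lies compound 2 at 1000000 nM.

The next compound to be tested is compound 4 `COC(=O)C1=C(C)N=C(C)/C(=C(\O)OC)C1c1ccccc1Br`. It has bromo in place of trifluoromethyl on an aromatic carbon of a six-membered aromatic ring of carbon only, ortho to a large group: bromo in place of trifluoromethyl on an aromatic carbon. Everything else in the structure stays the same as in compound 3.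

Among the measured compounds shown here, no two measured compounds differ in one place only, so the data hold no direct precedent for this exchange. The very wide spread between compound 3 and compound 2 shows that the aromatic substituents can matter a great deal in this assay, but it does not isolate the effect of any single group. A modest step towards a higher number seems the most likely outcome, though a result within the scatter of compound 3 would not be surprising. The estimated change is a 2.6-fold higher number from compound 3 to compound 4 (0.42 log units; beyond the scatter). For compound 4 the expected value is 4 nM, with an estimated range from 1 nM to 20 nM.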

Compound 4, half-maximal effective concentration: 7.59 nM
Compound 4: middle estimate off by 1.9-fold (0.28 log units), on the low side; the measured number falls inside the stated range.
By their numbers in this assay, from the lowest: compound 3; then compounds 1 and 4 (each within the scatter of the next); then compound 2.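

With compound 3 and compound 4, this assay gains its first pair that differs in one place only, and bromo in place of trifluoromethyl on this aromatic carbon, ortho to a large group, gives a 5.0-fold higher number from compound 3 to compound 4 (0.70 log units; beyond the scatter). The exchange of four heavy atoms for one therefore moves the number beyond the scatter, yet compound 4 still reads 7.59 nM, so trifluoromethyl is not required at this place for a low number, although the lower number of this pair belongs to the compound that carries it. No measurement that could account for this step is available.

Among the compounds shown here, the single step does not show whether the shift is particular to bromo or would also appear with a chloro, nitro or amino group on the same carbon, or with plain hydrogen there. Nor do the compounds shown tell whether the same exchange would give a step of similar size on another aromatic carbon of this ring, or when other groups on the ring are changed at the same time.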